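The source may hold more compounds than are shown below. What is called first, only, known or untested is meant among the compounds shown, and "the series" means these compounds.

Compound 3 `COc1ccc(-c2cn(-c3cccc(C(=O)/C=C/c4ccc(O)c(OC)c4)c3)c(=O)[nH]2)cc1` carries the highest number of the three compounds measured in a functional assay on SNB-19 cells (Homo sapiens) for inhibition; on this read-out lower numbers stand for stronger inhibition of growth and higher numbers for weaker inhibition of growth. Compound 3 gives 5840 nM. Its nearest neighbour is compound 1 `COc1cc(/C=C/C(=O)c2cccc(-n3cc(-c4ccccc4)[nH]c3=O)c2)ccc1O`, which in this assay gives 2960 nM, so that the pair a 2.0-fold higher number from compound 1 to compound 3 (0.30 log units; within the scatter) lies within the scatter. The furthest is compound 2 `O=C(/C=C/c1cccc(O)c1)c1cccc(-n2cc(-c3ccc(Cl)cc3)[nH]c2=O)c1`, which gives 1920 nM; compound 2 differs from compound 3 in more than one place, so nothing can be read from that gap about any single change.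

Compound 4 `COc1cc(/C=C/C(=O)c2cccc(-n3cc(-c4ccc(Cl)cc4)[nH]c3=O)c2)ccc1O` arises from compound 3 by chloro in place of methoxy on an aromatic carbon. Within the data shown here, no measured pair isolates this change. Among the measured compounds shown here, the only step close to it, that from hydrogen to methoxy on the same aromatic carbon, was small and within the scatter, which suggests that this position tolerates change without a large shift. Compound 2 does carry the chloro group on this ring, and its value sits at the low end of the three, but its other ring differs as well, so it offers only a hint of direction.

Compound 4 is therefore expected to land near compound 1 or slightly lower, with the step of a 2.9-fold lower number from compound 3 to compound 4 (0.47 log units; beyond the scatter) estimated to be modest. The estimate for compound 4 is 2000 nM, with a range from 800 nM to 5000 nM.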

Compound 4, concentration for 50% growth inhibition: 3170 nM
The estimate for compound 4 lay 1.6-fold (0.20 log units) below the measured number; the range from low to high includes it.
By their numbers in this assay, from the lowest: compounds 2, 1, 4 and 3 (each within the scatter of the next, the first and the last beyond it).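

In this assay, the carbon para to a large group has now carried hydrogen, methoxy and chloro, and each exchange among the three stays within the scatter: chloro for methoxy (a 1.8-fold lower number from compound 3 to compound 4 (0.27 log units; within the scatter)), chloro for hydrogen (a 1.1-fold higher number from compound 1 to compound 4 (0.03 log units; within the scatter)) and methoxy for hydrogen (a 2.0-fold higher number from compound 1 to compound 3 (0.30 log units; within the scatter)). The earlier compounds shown here offered only the last of these steps, whereas compound 4 closes the set and also gives a single-place reading of the other end of the molecule, where 4-hydroxy-3-methoxyphenyl in place of 3-hydroxyphenyl likewise stays within the scatter (a 1.7-fold higher number from compound 2 to compound 4 (0.22 log units; within the scatter)). No data in hand say why these steps are small.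

The compounds shown leave open whether a group of another kind on this carbon, such as an amine or a carboxylic acid, would give a step beyond the scatter in this assay. They also leave open whether the steps seen here would stay this small on a different cell line, since every number shown comes from the one read-out.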